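Adding a Methyl Group to Compound 2

This account rests on a few compounds, and the source may have more. Where it says the series, first, only, none or still open, it means among the compounds named here.

Measured in a functional assay on PC-3 cells (Homo sapiens) for inhibition, read by sulforhodamine B assay, with a stated time of 48 h; on this read-out higher numbers stand for weaker inhibition of growth and lower numbers for stronger inhibition of growth:
Compound 1 `CC(C)(C)NCc1c(C(=O)O)nn(-c2ccc(Cl)cc2)c1-c1ccc(Cl)cc1`: > 599000 nM
Compound 2 `CC(C)(C)NCc1c(C(=O)O)nn(-c2ccc(Cl)cc2)c1-c1ccccc1`: > 652000 nM

Neither entry is a number. Compound 2 gives > 652000 nM, and this is a limit of the assay. Compound 1 gives > 599000 nM, and this too is a limit. So compound 2 has no exact place on the scale.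

Compound 3 `Cc1ccc(-c2c(CNC(C)(C)C)c(C(=O)O)nn2-c2ccc(Cl)cc2)cc1` differs from compound 2 by methyl in place of hydrogen on an aromatic carbon, turning phenyl into 4-methylphenyl.

Among the measured compounds shown here, only one measured step bears on this change: a step that the two limits leave unreadable from compound 1 to compound 2. It swaps chloro for hydrogen on an aromatic carbon, and it offers no size to borrow. No step beyond the usual scatter is therefore expected in this assay, and no direction can be named. The expected change is an at least 1.0-fold lower number from compound 2 to compound 3 (0.01 log units; that floor lies within the scatter). Compound 3 is estimated at 630000 nM, with an expected range from 250000 nM to 1000000 nM.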

Compound 3, concentration for 50% growth inhibition: > 629000 nM
Compound 3: no number, only a limit (the forecaster's own chance of this, stated with the estimate: 85%); the middle value lies beyond the limit too.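

Compound 3 gives > 629000 nM, which is a limit of the assay and not a number. Among the compounds shown here, compound 1 and compound 2 also have only limits, so no step among the three can be read. On these data alone, whether chloro, hydrogen or methyl in this place changes growth inhibition stays open.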